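From 2-bromobenzyl to 3-bromobenzyl: a small expected step

The compounds below may be only part of what the source reports. "The series", "measured", "known", "first", "only" and "open" are said of these compounds alone.

Measured so far in a functional assay on BGC-823 cells (Homo sapiens) for antiproliferative activity, read by MTT assay, with a stated time of 48 h; a lower number here means a stronger inhibitor, a higher number a weaker inhibitor:
- compound 1 `Fc1ccc(CSc2nnc(-c3cnccn3)o2)c(F)c1` gives 33000 nM
- compound 2 `Brc1ccccc1CSc1nnc(-c2cnccn2)n1-c1ccccc1` gives 36200 nM

Compound 2 stands level with compound 1, since their two values lie within the usual scatter of each other. Compound 3 `Brc1cccc(CSc2nnc(-c3cnccn3)n2-c2ccccc2)c1` differs from compound 2 by having 3-bromophenyl in place of 2-bromophenyl on a saturated chain carbon bound to a sulfur. Within the data shown here, no measured pair shows the effect of such a change, so no step beyond the scatter is expected in this assay here. The estimated change, a 1.2-fold lower number from compound 2 to compound 3 (0.08 log units; within the scatter), is therefore small. The estimate for compound 3 is 30000 nM (expected range 12000 nM to 70000 nM).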

Compound 3, half-maximal inhibitory concentration: 18300 nM
For compound 3 the middle estimate is 1.6-fold (0.21 log units) above the measured one; the range from low to high includes it.
By their numbers in this assay, from the lowest: compounds 3, 1 and 2 (each within the scatter of the next).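

Among these compounds, this pair gives the first direct reading of this change on a saturated chain carbon bound to a sulfur: in this assay, 3-bromobenzyl in place of 2-bromobenzyl gives a 2.0-fold lower number from compound 2 to compound 3 (0.30 log units; within the scatter). The two bromine placements therefore cannot be told apart in this assay, although the step sits at the edge of the usual scatter. Nothing measured here offers a reason for the result. Still open, as far as these compounds go, is whether 4-bromobenzyl, or a benzyl group carrying an amine or a carboxylic acid instead of bromine, would give a value clearly different from compound 2.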